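Methoxy added to the phenol of compound 1

The compounds below may be only part of what the source reports. "The series", "measured", "known", "first", "only" and "open" are said of these compounds alone.

For the measured compounds named here, compound 1 `Oc1ccc(/C=N/n2cnnc2)cc1` gives 2990 nM in an assay for inhibition of Alpha amylase (Homo sapiens), with a stated time of 10 min (on this read-out lower numbers stand for stronger inhibition and higher numbers for weaker inhibition), the lowest of the three numbers so far, though both other compounds lie within the scatter of it. Compound 2 `Oc1ccc(/C=N/n2cnnc2)c(O)c1` gives 5950 nM and compound 3 `Clc1ccc(/C=N/n2cnnc2)cc1` gives 4360 nM. Both measured steps are small: a 2.0-fold higher number from compound 1 to compound 2 (0.30 log units; within the scatter) and a 1.5-fold higher number from compound 1 to compound 3 (0.16 log units; within the scatter). Compound 4 `COc1cc(/C=N/n2cnnc2)ccc1O` differs from compound 1 by methoxy in place of hydrogen on an aromatic carbon. The step from compound 1 to compound 2 bears on this most closely, as it is also an addition of a small group on the aromatic ring of carbon only, and it stayed within the scatter; the step from compound 1 to compound 3 likewise shows a change on that ring without a shift beyond the scatter. Going by the values given here, no measured step points to a move beyond the scatter in this assay, so the expected step is a 1.2-fold higher number from compound 1 to compound 4 (0.08 log units; within the scatter), leaning if anything toward a slightly higher number as seen for compound 2. Compound 4 is therefore estimated at 3600 nM, with a range from 1500 nM to 8500 nM.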

Compound 4, half-maximal inhibitory concentration: 5940 nM
The estimate for compound 4 lay 1.7-fold (0.22 log units) below the measured number, within the range that was stated.
By their numbers in this assay, from the lowest: compounds 1, 3, 4 and 2 (each within the scatter of the next).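

The position ortho to a hydroxy group accepts methoxy in this assay, with a 2.0-fold higher number from compound 1 to compound 4 (0.30 log units; within the scatter), so this carbon takes a group of 2 heavy atoms in place of hydrogen with the phenol hydroxy retained. This adds a second substituent type to the ring changes shown here, and it stays within the scatter just as the hydroxy addition does in a 2.0-fold higher number from compound 1 to compound 2 (0.30 log units; within the scatter). No measurement on hand explains the size of this step.

On these data alone, it remains open whether a longer chain such as ethoxy, an amine or a carboxylic acid on this same carbon would give a step beyond the scatter. With every step in the series so far inside the scatter, the compounds shown also do not establish which part of the shared core governs the number.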